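Alkynyl substituents on the shared core: hydroxymethyl removed

The compounds below may be only part of what the source reports. "The series", "measured", "known", "first", "only" and "open" are said of these compounds alone.

Measured compounds:
compound 1 `CN1CCC[C@H]1COc1cccnc1` — 1.9 nM
compound 2 `CN1CCC[C@H]1COc1cncc(C#CC(C)(C)O)c1` — 2.9 nM
compound 3 `CN1CCC[C@H]1COc1cncc(C#CCO)c1` — 0.93 nM

In an assay on a protein complex for binding affinity to Neuronal acetylcholine receptor; alpha4/beta2 (Rattus norvegicus) (on this read-out higher numbers stand for weaker inhibition and lower numbers for stronger inhibition), compound 3 gives the lowest of the three numbers. The step from compound 1 to compound 3 was a 2.0-fold lower number from compound 1 to compound 3 (0.31 log units; beyond the scatter), the step from compound 2 to compound 3 was a 3.1-fold lower number from compound 2 to compound 3 (0.49 log units; beyond the scatter), and the step from compound 1 to compound 2 was a 1.5-fold higher number from compound 1 to compound 2 (0.18 log units; within the scatter).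

Compound 4 `C#Cc1cncc(OC[C@@H]2CCCN2C)c1` carries the change (hydrogen in place of hydroxymethyl on a triple-bonded carbon), so that the alkyne terminates in a bare hydrogen. Among the measured compounds shown here, two measured steps bear on it: the gain on going from compound 1 to compound 3, and the loss on going from compound 3 to compound 2, which together show that the group at the end of the alkyne shifts the number only modestly in either direction. An ethynyl group sits between hydrogen on the aromatic carbon and the hydroxymethyl-capped alkyne, so the expected step of a 1.6-fold higher number from compound 3 to compound 4 (0.21 log units; within the scatter) is small, most likely a slightly higher number than compound 3 but not beyond the scatter. The estimate for compound 4 in this assay is 1.5 nM, with a range from 0.6 nM to 4 nM.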

Compound 4, inhibition constant: 1.6 nM
Compound 4: middle estimate off by 1.1-fold (0.03 log units), on the low side, and the stated range covers the measured number.
By their numbers in this assay, from the lowest: compounds 3, 4, 1 and 2 (each within the scatter of the next, the first and the last beyond it).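

In this assay, a 1.7-fold higher number from compound 3 to compound 4 (0.24 log units; within the scatter) shows that the 3-hydroxyprop-1-yn-1-yl group can be cut back to ethynyl without a step beyond the scatter, so the hydroxymethyl is not required for a number in this range. With a 1.2-fold lower number from compound 1 to compound 4 (0.07 log units; within the scatter) for ethynyl in place of hydrogen on the aromatic carbon and a 1.8-fold lower number from compound 2 to compound 4 (0.26 log units; within the scatter) for hydrogen in place of 1-hydroxy-1-methylethyl, compound 4 cannot be ordered against any of the other three compounds. The bare alkyne therefore sits with all of them, although compound 2 and compound 3 remain separated beyond the scatter.

Going by these compounds, whether an amine, a carboxylic acid or a longer chain at the end of the alkyne would move the number further remains open. No measurement shown explains these small steps.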